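The source may hold more compounds than are shown below. What is called first, only, known or untested is meant among the compounds shown, and "the series" means these compounds.

Working notes on the series.

Compound 1 `COc1ccccc1/C=C/C(=O)c1cc(NC(C)=O)ccc1O` and compound 2 `CC(=O)Nc1ccc(O)c(C(=O)/C=C/c2ccccc2F)c1` share one core. Compound 3 `COc1cccc(-c2cc(=O)c3cc(N)ccc3o2)c1` and compound 4 `Nc1ccc2oc(-c3cccc(F)c3)cc(=O)c2c1` share another, and the difference between the two cores is not broken down here.

In an ADME assay on THP-1 cells (Homo sapiens) for cytotoxicity, read by flow cytometry and propidium iodide staining, with a stated time of 72 h (on this read-out higher numbers stand for weaker inhibition and lower numbers for stronger inhibition), compound 1 gives > 125000 nM, which is a limit of the assay and not a number. In this assay compound 2 gives > 125000 nM, again a limit only. In this assay compound 3 gives > 125000 nM, also a limit only.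

The change from compound 1 to compound 2 is fluoro in place of methoxy on an aromatic carbon. Among the measured compounds shown here, the step that the two limits leave unreadable from compound 1 to compound 2 cannot be read because the limit of > 125000 nM in this assay, at which 3 of the 3 values shown sit, holds both values, so no size of step is available from the measured pair.

The change from compound 3 to compound 4 is fluoro in place of methoxy on an aromatic carbon. For the measured compounds named here, it is the same kind of change as the one between compound 1 and compound 2, not the same change: in compound 1 the methoxy sits ortho to a large group, while in compound 3 it sits meta to a large group.

Since every value shown so far rests on (the limit of > 125000 nM in this assay, at which 3 of the 3 values shown sit), the expected step that the limit leaves unreadable from compound 3 to compound 4 is estimated to be small or unreadable, which rests only on compound 1, compound 2 and compound 3 all sitting at the limit. Compound 4 is therefore expected to give about 200000 nM, most likely reported again only as a limit, with the estimated range running from 60000 nM to 600000 nM.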

Compound 4, half-maximal inhibitory concentration: > 125000 nM
Compound 4 ended at the assay's limit (the forecaster's own chance of this, stated with the estimate: 85%); the middle value lies beyond the limit too.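

In this assay compound 3 and compound 4 both end at a limit and not at a number, so no size can be read for the step between them: the limit of > 125000 nM in this assay, at which 4 of the 4 values shown sit.

The compounds shown leave open what fluoro in place of methoxy does in this assay on either core, and whether the two cores differ at all on this read-out.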